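Expected Clearance When One Methyl Leaves Compound 3

The source may hold more compounds than are shown below. What is called first, only, known or untested is meant among the compounds shown, and "the series" means these compounds.

Three compounds have numbers in an ADME assay on cells (Hepatocyte, Rattus norvegicus, strain Wistar) for pharmacokinetics, read by LC-MS, with a stated time of 90 min, tested at 1 uM (a higher number here means faster removal of the compound, a lower number slower removal), so far: compound 1 `COc1cc(C(=O)N2CCC(O)CC2)cc2nc(NCc3cccc(Cl)c3)oc12` (21.7 mL/min/kg), compound 2 `COc1cc(C(=O)N2CC[C@@H](O)[C@H](C)C2)cc2nc(NCc3cccc(Cl)c3)oc12` (38.3 mL/min/kg) and compound 3 `COc1cc(C(=O)N2CC(C)(CCO)OC[C@H]2C)cc2nc(N[C@H](C)c3cccc(Cl)c3)oc12` (58.3 mL/min/kg). Compound 3 lies beyond the scatter above compound 1 and within the scatter of compound 2. Compound 4 `COc1cc(C(=O)N2C[C@@H](C)OC[C@H]2CCO)cc2nc(N[C@H](C)c3cccc(Cl)c3)oc12` differs from compound 3 only in the group on a carbonyl carbon, where 5-(2-hydroxyethyl)-2-methylmorpholin-4-yl takes the place of 2-(2-hydroxyethyl)-2,5-dimethylmorpholin-4-yl (5-(2-hydroxyethyl)-2-methylmorpholin-4-yl in place of 2-(2-hydroxyethyl)-2,5-dimethylmorpholin-4-yl on a carbonyl carbon), so one methyl is lost. For the measured compounds named here, only one measured step touches such a change, methyl in place of hydrogen on a saturated ring carbon (a 1.8-fold higher number from compound 1 to compound 2 (0.25 log units; within the scatter)). It runs the opposite way, on a different group, so at most a slight fall within the scatter is expected. Going by the values given here, no measured step covers the new place of the hydroxyethyl. The estimated step is small (a 1.2-fold lower number from compound 3 to compound 4 (0.08 log units; within the scatter)) and stays within the scatter. For compound 4 the estimated clearance is (48 mL/min/kg) within an expected range (28 mL/min/kg to 75 mL/min/kg).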

Compound 4, clearance: 38.3 mL/min/kg
Compound 4: middle estimate off by 1.3-fold (0.10 log units), on the high side, and the stated range covers the measured number.
By their numbers in this assay, from the lowest: compounds 1, 2, 4 and 3 (each within the scatter of the next, the first and the last beyond it).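

In this assay, the group on the carbonyl carbon could be rearranged without a change beyond the scatter: 5-(2-hydroxyethyl)-2-methylmorpholin-4-yl in place of 2-(2-hydroxyethyl)-2,5-dimethylmorpholin-4-yl gives a small step (a 1.5-fold lower number from compound 3 to compound 4 (0.18 log units; within the scatter)). The earlier compounds shown here showed only a methyl added to a hydroxypiperidine-type amide, whereas this pair shows that losing one methyl and moving the hydroxyethyl together, with the defined stereocentres going from one to two in this group, leaves the reading within the scatter. Nothing available accounts for this result.

The two changes arrive in a single step, so the share of the lost methyl and that of the moved hydroxyethyl cannot be told apart. The compounds shown also leave open how this position would read with an amine or a carboxylic acid in place of the hydroxyl, or with a longer chain.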